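This account rests on a few compounds, and the source may have more. Where it says the series, first, only, none or still open, it means among the compounds named here.

Compound 1: `CCCCCCCCCCCCCCNC(=O)[C@@H](NC(=O)c1ccco1)[C@@H](C)O` — 190000 nM
Compound 2: `C/C=C/C=C/C(=O)N[C@H](C(=O)NCCCCCCCCCCCCCC)[C@@H](C)O` — > 200000 nM

In a functional assay on A-431 cells (Homo sapiens) for cytotoxicity, read by MTT assay, with a stated time of 48 h (a higher number here means a weaker inhibitor, a lower number a stronger inhibitor), compound 1 gives 190000 nM. Compound 2 gives no number in this assay but only a limit, > 200000 nM. Compound 2 therefore sits at the limit of > 200000 nM in this assay, at which 1 of the 2 values shown sits, and the step of an at least 1.0-fold higher number from compound 1 to compound 2 (0.02 log units; that floor lies within the scatter) lies within the scatter. The next compound, compound 3 `CCCCCCCCCCCCCCNC(=O)[C@@H](NS(=O)(=O)c1ccc(C)cc1)[C@@H](C)O`, differs from compound 2 in one place: (4-methylphenyl)sulfonyl in place of (penta-1,3-dien-1-yl)carbonyl on an amine nitrogen. Going by the values given here, no measured step swaps a carbonyl for a sulfonyl on this nitrogen, so the only guide is that the two groups tried there both leave this cell line almost untouched. The step of a number no higher from compound 2 to compound 3 (the limit leaves the size open) is therefore expected to be none beyond the scatter, with a good chance that this assay again reports only a limit. Compound 3 is estimated at 200000 nM, within 80000 nM to 400000 nM.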

Compound 3, half-maximal inhibitory concentration: 12000 nM
For compound 3 the middle estimate is 17-fold (1.22 log units) above the measured one; the whole stated range lies above it.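

On the amine nitrogen, the earlier swap between two carbonyl groups showed nothing beyond the scatter, so this position looked unresponsive in this assay. A sulfonyl group changes that picture: putting (4-methylphenyl)sulfonyl in place of (furan-2-yl)carbonyl gives a 16-fold lower number from compound 1 to compound 3 (1.20 log units; beyond the scatter), so what sits on this nitrogen can matter a great deal for this cell line. Putting it in place of (penta-1,3-dien-1-yl)carbonyl gives an at least 16-fold lower number from compound 2 to compound 3 (1.22 log units; beyond the scatter), a size that is only a floor: the limit of > 200000 nM in this assay, at which 1 of the 3 values shown sits.

The compounds shown cannot separate the sulfonyl link from the 4-methylphenyl group, since these two enter together; a benzoyl group or a methylsulfonyl group on the same nitrogen would pull them apart. As far as these compounds go, whether a shorter chain in place of the long one keeps this gain also remains open.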